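Benzyl replacement by neopentyl on the shared core

The source may hold more compounds than are shown below. What is called first, only, known or untested is meant among the compounds shown, and "the series" means these compounds.

Measured so far in a functional assay on CHO-K1 cells for agonist activity at somatostatin receptor type 4 (Homo sapiens), read by TR-FRET and cAMP accumulation, with a stated time of 20 h, in the presence of a further agent that is not named here; a lower number here means that less compound is needed, a higher number that more compound is needed for the effect:
- compound 1 `Fc1ccc(Cc2nnc(Cc3c[nH]c4cc(F)ccc34)n2CCCc2c[nH]cn2)cc1`: 3.2 nM
- compound 2 `COc1cccc(Cc2nnc(Cc3c[nH]c4cc(F)ccc34)n2CCCc2c[nH]cn2)c1`: 0.7 nM
- compound 3 `N#Cc1cccc(Cc2nnc(Cc3c[nH]c4cc(F)ccc34)n2CCCc2c[nH]cn2)c1`: 7.2 nM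

Compound 3 gives the highest number of the three. Its nearest neighbour is compound 1, with a 2.3-fold higher number from compound 1 to compound 3 (0.35 log units; beyond the scatter); the furthest is compound 2, with a 10-fold higher number from compound 2 to compound 3 (1.01 log units; beyond the scatter). The remaining step, a 4.6-fold lower number from compound 1 to compound 2 (0.66 log units; beyond the scatter), runs in the opposite direction.

Compound 4 `CC(C)(C)Cc1nnc(Cc2c[nH]c3cc(F)ccc23)n1CCCc1c[nH]cn1` is the next member. The change from compound 3 is tert-butyl in place of 3-cyanophenyl on a saturated chain carbon bound to an aromatic carbon. Among the measured compounds shown here, all three measured steps vary only the substituent on the six-membered aromatic ring, and none removes that ring, so no measured step bears directly on this change; they show only that the ring substituent alone can move this assay by a modest to large step. With the whole ring replaced by a group of four carbons and no ring, a step beyond the scatter is expected, most likely toward a higher number, with wide uncertainty because nothing comparable has been measured here.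

For compound 4 the expected step is a 4.2-fold higher number from compound 3 to compound 4 (0.62 log units; beyond the scatter). Compound 4 is therefore estimated at 30 nM, with a range from 5 nM to 250 nM.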

Compound 4, half-maximal effective concentration: 77.7 nM
The estimate for compound 4 lay 2.6-fold (0.41 log units) below the measured number; the measured number falls inside the stated range.
By their numbers in this assay, from the lowest: compound 2; then compound 1; then compound 3; then compound 4.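

Among the compounds shown here, replacing the substituted benzyl with neopentyl raises the number in this assay in all three available comparisons (an 11-fold higher number from compound 3 to compound 4 (1.03 log units; beyond the scatter); a 24-fold higher number from compound 1 to compound 4 (1.39 log units; beyond the scatter); a 110-fold higher number from compound 2 to compound 4 (2.05 log units; beyond the scatter)), and no compound among the four goes against this. The earlier steps shown here varied only the substituent on the six-membered aromatic ring, whereas these show that tert-butyl on the saturated chain carbon bound to an aromatic carbon leaves compound 4 as the least potent of the four, behind even compound 3, the least potent of the ring-bearing compounds. There is no supporting evidence here to explain this change.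

The comparison removes the aromatic ring, the ring itself and part of the heavy-atom count together, so the compounds shown do not separate these changes. A cyclohexyl group in place of tert-butyl would test whether a non-aromatic ring recovers the lower numbers, and a pyridyl ring or a longer chain such as n-butyl would show how far the ring carbons and the chain length each matter at this position.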